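The source may report more compounds than this note shows. Statements on the series, on what has been measured and on what is new or still open speak of the compounds shown alone.

Measured so far in an assay on CHO cells for displacement of a labelled ligand from adenosine receptor A3 (Homo sapiens), read by scintillation counting, tested at 10 uM; a lower number here means less inhibition, a higher number more inhibition at the concentration tested (going by the name of the read-out):
Compound 1 `CC(C)(C)Cc1c(-c2ccccc2)sc(N)c1C(=O)c1ccccc1Cl` gives 1%.
Compound 2 `CC(C)(C)Cc1c(-c2ccccc2)sc(N)c1C(=O)c1ccc(Cl)cc1Cl` gives 1%.
Compound 3 `COc1ccc(-c2sc(N)c(C(=O)c3cccc(Cl)c3)c2CC(C)(C)C)cc1` gives 2%.

Compound 1 and compound 3 differ in their cores, and the difference between the two cores is not broken down here. Compound 2 differs from compound 1 by chloro in place of hydrogen on an aromatic carbon; the step of no change at the digits printed from compound 1 to compound 2 (within the scatter). Compound 4 `COc1ccc(-c2sc(N)c(C(=O)c3ccc(Cl)c(Cl)c3)c2CC(C)(C)C)cc1` is unmeasured and differs from compound 3 by chloro in place of hydrogen on an aromatic carbon. This is the same kind of change as from compound 1 to compound 2, though the place differs: in compound 2 the entering chloro is meta to a chloro group, while in compound 4 it is ortho to a chloro group. Because no change at the digits printed from compound 1 to compound 2 (within the scatter) was flat, the step of a number 1 percentage points higher from compound 3 to compound 4 (within the scatter) is expected to stay small in this assay. Compound 4 is therefore estimated at 3%, between 0% and 12%.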

Compound 4, a percentage reported as inhibition, at one concentration (the size of the read-out at that concentration, not a potency): 1%
The estimate for compound 4 lay 2 percentage points above the measured number, within the range that was stated.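

In this assay, the change from 3-chlorophenyl to 3,4-dichlorophenyl gives a number 1 percentage points lower from compound 3 to compound 4 (within the scatter). Set beside the earlier step, the same change reads alike on the two cores, although the entering chloro sits in a different place on each: the same change on two cores in this assay, no change at the digits printed (within the scatter) from compound 1 to compound 2 and a number 1 percentage points lower (within the scatter) from compound 3 to compound 4, 1 percentage points apart, within the scatter of two such steps. This does not show that the change would stay flat on a compound with clear inhibition, as none of the four compounds shown has any, and two pairs cannot establish a rule for the series.

The compounds shown leave open whether an amine or a carboxylic acid in place of the chloro would alter the reading in this assay.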